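The source may report more compounds than this note shows. Statements on the series, on what has been measured and on what is new or still open speak of the compounds shown alone.

The study concerns two compounds that share a core and differ in a single group on the six-membered aromatic ring. Compound 1 is `COc1ccc(/C=N/NC(=N)NO)cc1` and compound 2 is `Cc1ccccc1/C=N/NC(=N)NO`. Both have been examined in an ADME assay on Vero cells (Chlorocebus sabaeus) for cytotoxicity; a higher number here means that more compound is tolerated, a lower number that less compound is tolerated. For compound 1 the result is a limit of the assay rather than a number: compound 1 gives > 100000 nM. Compound 2 likewise reaches only a limit: in this assay compound 2 gives > 100000 nM. Where compound 2 stands is thus fixed only by that boundary, and the limit of > 100000 nM in this assay, at which 2 of the 2 values shown sit, is all the two measurements show; no order between them can be read.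

The step under consideration leads to compound 3, `N=C(NO)N/N=C/c1ccccc1`. Relative to compound 2 the change is hydrogen in place of methyl on an aromatic carbon. Going by the values given here, no measured pair in this set isolates such a change. Because the limit of > 100000 nM in this assay, at which 2 of the 2 values shown sit, holds for both measured compounds, no step beyond the scatter is expected in either direction, and the step is estimated as a number no higher from compound 2 to compound 3 (the limit leaves the size open). Compound 3 is therefore expected to give 100000 nM, within a range from 50000 nM to 200000 nM, most likely again only as a limit of the assay.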

Compound 3, half-maximal cytotoxic concentration: > 100000 nM
Compound 3 was reported as a limit; the forecaster's own chance of this, stated with the estimate: 85%; the middle value sits exactly at the limit.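

In this assay compound 3 gives > 100000 nM, which is a limit of the assay. No step from compound 1 or compound 2 to compound 3 can be read: the limit of > 100000 nM in this assay, at which 3 of the 3 values shown sit.

The compounds shown leave open where the half-maximal cytotoxic concentration of each lies, and whether hydrogen, methyl or methoxy on the aromatic carbon makes any difference in this assay.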